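Working notes on solubility in a small aryl series

The source may hold more compounds than are shown below. What is called first, only, known or untested is meant among the compounds shown, and "the series" means these compounds.

compound 1 `COc1ccccc1Oc1ccc2c(NCCCNCc3ccco3)ccnc2c1` — 14500 nM
compound 2 `COc1ccc(F)cc1CNCCCNc1ccnc2cc(Cc3cccc(C(F)(F)F)c3)ccc12` — 4200 nM

In a physicochemical assay for solubility, with a stated time of 18 h, at pH 7.4 (a lower number here means a less soluble compound, a higher number a more soluble compound), compound 1 gives 14500 nM and stands highest of the two numbers; compound 2 gives 4200 nM, a gap beyond the scatter.

Compound 3 `CN(C)c1cccc(Oc2ccc3c(NCCCNCc4ccco4)ccnc3c2)c1` is not yet measured. It differs from compound 1 in one place: 3-(dimethylamino)phenyl in place of 2-methoxyphenyl on an oxygen on an aromatic ring. Among the measured compounds shown here, no step between measured compounds touches this position, so the expectation rests on compound 1 alone. The expected step is a 1.2-fold lower number from compound 1 to compound 3 (0.08 log units; within the scatter), none beyond the scatter. Compound 3 is estimated at 12000 nM, with a range from 4000 nM to 35000 nM.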

Compound 3, solubility: 14500 nM
The estimate for compound 3 lay 1.2-fold (0.08 log units) below the measured number; low and high end bracket the measured number.
By their numbers in this assay, from the lowest: compound 2; then compounds 1 and 3 (each within the scatter of the next).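

In this assay this position now has its first reading: 3-(dimethylamino)phenyl in place of 2-methoxyphenyl on an oxygen on an aromatic ring gives no change at the digits printed from compound 1 to compound 3 (within the scatter) and the read-out does not separate these two groups. The position therefore accepts this exchange without a change beyond the scatter, though this rests on a single pair. No measurement at hand explains the result.

Still open, from the compounds shown here alone, is whether a carboxylic acid or a morpholine on the same oxygen would move the number, and whether the same exchange would behave alike with a different chain on the shared core.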